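A Larger Ring-Bearing Group on the Shared Core

A few compounds are considered here, and "the series" means these few. Any claim that something is new, unique, unknown or untested is made for them only; others in the source may bear on it.

Measured so far in a functional assay on A549 cells (Homo sapiens) for antiproliferative activity, read by MTT assay, with a stated time of 48 h; a higher number here means a weaker inhibitor, a lower number a stronger inhibitor:
compound 1 `CCOc1cc(-c2ccc3ccn(C)c3c2)cn2c(-c3cc(OC)c(OC)c(OC)c3)nnc12`: 349 nM
compound 2 `COc1cc(-c2nnc3c(OC(C)C)cc(-c4ccc5c(ccn5C)c4)cn23)cc(OC)c1OC`: 322 nM

Compound 2 stands level with compound 1, as the gap between their two values lies within the usual scatter of repeated measurements, so the pair cannot be ranked. Compound 3 `CCCN1CC(Oc2cc(-c3ccc4c(ccn4C)c3)cn3c(-c4cc(OC)c(OC)c(OC)c4)nnc23)C1` differs from compound 2 in one place, with 1-propylazetidin-3-yl in place of isopropyl on an oxygen on an aromatic ring. Among the measured compounds shown here, no two measured compounds differ in just one place, so the data offer no direct measure of what such a swap does in this assay. The swap is a sizeable one, so a modest weakening is expected, and the range is kept wide. The estimated step of a 2.2-fold higher number from compound 2 to compound 3 (0.34 log units; beyond the scatter) lies near the edge of the scatter. For compound 3 the expected value is 700 nM (180 nM to 2700 nM).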

Compound 3, half-maximal inhibitory concentration: 234 nM
Beside the measured number, compound 3's estimate is 3.0-fold (0.48 log units) above it; measured number inside the range.
By their numbers in this assay, from the lowest: compounds 3, 2 and 1 (each within the scatter of the next).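

The change from isopropyl to 1-propylazetidin-3-yl on the oxygen gives a 1.4-fold lower number from compound 2 to compound 3 (0.14 log units; within the scatter) in this assay, so compound 2 and compound 3 stand level. Among the compounds shown here, this is the first direct reading at this position, and it shows that the much larger group, with its four-membered ring and its nitrogen, leaves the number within the scatter of the one for the plain isopropyl group. Nothing measured here says why the two compounds read alike.

The compounds shown do not separate what the ring and the propyl chain each contribute, and a methyl group in place of that propyl chain would be one way to probe this. Going by these compounds, whether the ring is needed at all also stays open, as does whether an open-chain amine such as 2-(dimethylamino)ethyl would read the same on this oxygen.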